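Benzyl in Place of Difluorophenyl on the Saturated Ring Carbon

This account rests on a few compounds, and the source may have more. Where it says the series, first, only, none or still open, it means among the compounds named here.

Measured compounds:
compound 1, `O=C1Nc2c(ccc(F)c2F)C1(c1ccc(O)cc1)c1ccc(F)c(F)c1`, 19 nM
compound 2, `O=C1Nc2c(ccc(F)c2F)C1(c1ccc(O)cc1)c1cccs1`, 0.3 nM

In a functional assay on PC-3 cells (Homo sapiens) for cytotoxicity, read by WST assay, with a stated time of 72 h (a higher number here means a weaker inhibitor, a lower number a stronger inhibitor), compound 1 gives the highest of the two numbers; its nearest neighbour is compound 2, with a 63-fold lower number from compound 1 to compound 2 (1.80 log units; beyond the scatter). Compound 3, `O=C1Nc2c(ccc(F)c2F)C1(Cc1ccccc1)c1ccc(O)cc1`, differs from compound 1 in one place: benzyl in place of 3,4-difluorophenyl on a saturated ring carbon. Within the data shown here, the only measured step, from compound 1 to compound 2, also exchanges the 3,4-difluorophenyl group on a saturated ring carbon, and it was large, but the entering group there was thiophen-2-yl rather than benzyl, so it does not tell the direction for this change. Among the measured compounds shown here, no measured step bears directly on benzyl in place of 3,4-difluorophenyl, and the expectation is therefore uncertain, with a step of modest size in either direction plausible. In this assay compound 3 is expected to give about 40 nM, with a range from 5 nM to 300 nM. This estimate corresponds to a 2.1-fold higher number from compound 1 to compound 3 (0.32 log units; beyond the scatter).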

Compound 3, half-maximal inhibitory concentration: > 1000 nM
Compound 3: no number, only a limit (the forecaster's own chance of this, stated with the estimate: 5%); at least 25-fold (1.39 log units) between middle value and limit.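

Compound 3 has no number in this assay, only a limit of the assay: the limit of > 1000 nM in this assay, at which 1 of the 3 values shown sits. Even so, benzyl in place of 3,4-difluorophenyl on the saturated ring carbon gives an at least 52-fold higher number from compound 1 to compound 3 (1.72 log units; beyond the scatter), and benzyl in place of thiophen-2-yl gives an at least 3300-fold higher number from compound 2 to compound 3 (3.52 log units; beyond the scatter). Benzyl also holds one six-membered aromatic ring of carbon only, so among these three compounds an aromatic ring in the entering group does not by itself keep the number low at this position.

The limit leaves the true size of both steps open. The compounds shown also do not tell how an unsubstituted phenyl, a longer chain such as 2-phenylethyl, or an amine would behave on this carbon.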